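The source may report more compounds than this note shows. Statements on the series, on what has been measured and on what is new or still open speak of the compounds shown alone.

Measured in an assay on HEK293 cells for displacement of a labelled ligand from Melanocortin receptor 4 (Homo sapiens); on this read-out lower numbers stand for stronger inhibition and higher numbers for weaker inhibition:
compound 1 `CC(C)[C@H](NC(=O)CCN(C)C)c1ccccc1N1CCN(C(=O)[C@H](C)Cc2ccc(Cl)cc2)CC1` gives 24 nM
compound 2 `CC(C)[C@H](N)c1cccc(F)c1N1CCN(C(=O)[C@H](C)Cc2ccc(Cl)cc2)CC1` gives 83 nM
compound 3 `CC(C)[C@H](N)c1cc(Cl)ccc1N1CCN(C(=O)[C@H](C)Cc2ccc(Cl)cc2)CC1` gives 210 nM

Among these three, compound 3 has the highest number and thus the weakest binding. Compound 2 sits below it by a gap beyond the usual scatter, and compound 1 sits farthest below. Compound 4 `CC(C)[C@H](N)c1ccccc1N1CCN(C(=O)[C@H](C)Cc2ccc(Cl)cc2)CC1` has not yet been measured. It differs from compound 3 in one respect: hydrogen in place of chloro on an aromatic carbon, so the chloro is simply gone. Going by the values given here, no measured pair shows this exact change, so the expectation rests on the neighbours. A modest step toward lower numbers, near the edge of the scatter, is expected a 2.6-fold lower number from compound 3 to compound 4 (0.42 log units; beyond the scatter), since the halogen-bearing analogue compound 2 gives 83 nM. Compound 4 is estimated at 80 nM, within a range from 30 nM to 250 nM.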

Compound 4, inhibition constant: 180 nM
Compound 4: middle estimate off by 2.3-fold (0.35 log units), on the low side, within the range that was stated.
By their numbers in this assay, from the lowest: compound 1; then compound 2; then compounds 4 and 3 (each within the scatter of the next).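

Hydrogen in place of the chloro para to a large group leaves binding within the scatter (a 1.2-fold lower number from compound 3 to compound 4 (0.07 log units; within the scatter)), so this chloro contributes nothing that can be measured here. The fluoro of compound 2 does count, as hydrogen in its place gives a real loss (a 2.2-fold higher number from compound 2 to compound 4 (0.34 log units; beyond the scatter)), and the larger loss comes at the amine nitrogen, with hydrogen in place of (2-(dimethylamino)ethyl)carbonyl (a 7.5-fold higher number from compound 1 to compound 4 (0.88 log units; beyond the scatter)). No measurement here explains these steps. On these data alone, whether a methyl, methoxy or fluoro at the chloro's position would shift binding stays open, as does a longer chain on the amine nitrogen.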